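The source may report more compounds than this note shows. Statements on the series, on what has been measured and on what is new or still open speak of the compounds shown alone.

Compound 3 `CN(C)S(=O)(=O)NC[C@@H]1CCCc2cc(S(=O)(=O)c3cccc(F)c3)ccc21` stands highest of the three numbers in an assay on isolated protein for displacement of a labelled ligand from 5-hydroxytryptamine receptor 6 (Homo sapiens) (on this read-out higher numbers stand for weaker inhibition and lower numbers for stronger inhibition), at 2 nM. Its nearest neighbour is compound 2 `CNS(=O)(=O)NC[C@@H]1CCCc2cc(S(=O)(=O)c3cccc(F)c3)ccc21`, which in this assay gives 1 nM; the step of a 2.0-fold higher number from compound 2 to compound 3 (0.30 log units; within the scatter) lies within the scatter, so no order between the two is claimed. The parent, compound 1 `NC[C@@H]1CCCc2cc(S(=O)(=O)c3cccc(F)c3)ccc21`, gives 0.0794 nM in this assay, and both substitutions on its amine nitrogen gave large steps, a 13-fold higher number from compound 1 to compound 2 (1.10 log units; beyond the scatter) and a 25-fold higher number from compound 1 to compound 3 (1.40 log units; beyond the scatter).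

Compound 4 `O=C1CN=C(NC[C@@H]2CCCc3cc(S(=O)(=O)c4cccc(F)c4)ccc32)N1` carries a group of 6 heavy atoms (3 carbon, 2 nitrogen, 1 oxygen; one five-membered non-aromatic ring with 2 hetero atoms) in place of a group of 6 heavy atoms (2 carbon, 1 nitrogen, 2 oxygen, 1 sulfur; no ring), on an amine nitrogen. For the measured compounds named here, no measured step exchanges one such group for another at this nitrogen. Going by the values given here, the steps that bear on it are those from compound 1 to compound 2 and from compound 1 to compound 3, which show that placing a group on the amine nitrogen raises the number well beyond the scatter, while the choice between methylsulfamoyl and dimethylsulfamoyl changes nothing beyond the scatter. Compound 4 is therefore expected to stay in the region of compounds 2 and 3 rather than return to the number of compound 1. The expected step is a 1.3-fold lower number from compound 3 to compound 4 (0.12 log units; within the scatter), none beyond the scatter. The estimate for compound 4 in this assay is 1.5 nM, with a range from 0.4 nM to 6 nM.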

Compound 4, inhibition constant: 0.1 nM
Compound 4: middle estimate off by 15-fold (1.18 log units), on the high side; measured number outside the range, below it.
By their numbers in this assay, from the lowest: compounds 1 and 4 (each within the scatter of the next); then compounds 2 and 3 (each within the scatter of the next).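

In this assay, a group on the amine nitrogen does not by itself raise the number: the group with one five-membered non-aromatic ring with 2 hetero atoms gives a 1.3-fold higher number from compound 1 to compound 4 (0.10 log units; within the scatter), whereas both sulfamoyl groups gave large steps from the same parent. Exchanging those groups for the ring-bearing group at this nitrogen gives a 20-fold lower number from compound 3 to compound 4 (1.30 log units; beyond the scatter) and a 10-fold lower number from compound 2 to compound 4 (1.00 log units; beyond the scatter), and the first of these exchanges keeps the count at 6 heavy atoms, so the identity of the group matters here and not only whether the nitrogen is substituted. No measurement at hand bears on the reason for this difference between the ring-bearing group and the sulfamoyl groups.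

The compounds shown leave open whether a plain methyl or an acetyl group on this amine nitrogen would give a number in the region of compounds 1 and 4 or in that of compounds 2 and 3. They also leave open whether the ring is needed at all, a question that an open-chain guanidine on the same nitrogen would address.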